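Swapping the methoxybenzyl arm of compound 1 for methoxyphenyl

This account rests on a few compounds, and the source may have more. Where it says the series, first, only, none or still open, it means among the compounds named here.

Compound 1 `C=C(Br)C(=O)Nc1cccc(-c2cn3nc(Cc4cccc(OC)c4)sc3n2)c1` was tested in a functional assay on CCRF-CEM cells (Homo sapiens) for inhibition, read by cell counting, with a stated time of 3 days (a higher number here means a weaker inhibitor, a lower number a stronger inhibitor), where compound 1 gives 3100 nM. Among the compounds with values here, its only measured companion is compound 2 `COc1cccc(Cc2nn3cc(-c4cccc(N)c4)nc3s2)c1`, which in this assay gives 40000 nM; the step of a 13-fold higher number from compound 1 to compound 2 (1.11 log units; beyond the scatter) is large and beyond the scatter, so compound 1 stands with the lowest of the two numbers known so far.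

Compound 3 `C=C(Br)C(=O)Nc1cccc(-c2cn3nc(-c4ccc(OC)cc4)sc3n2)c1` keeps the (1-bromoethenyl)carbonyl amide of compound 1 and changes the other end of the shared core: 4-methoxyphenyl in place of 3-methoxybenzyl on an aromatic carbon. Within the data shown here, no measured step touches this position; the single known step concerns the amide alone and says nothing about the group on the aromatic carbon of the five-membered aromatic ring with 2 nitrogen and 1 sulfur. The expectation for compound 3 therefore rests on compound 1 alone, with a step of a 1.3-fold higher number from compound 1 to compound 3 (0.11 log units; within the scatter) expected to stay within the scatter. Compound 3 is expected to give about 4000 nM in this assay, with a range from 1000 nM to 16000 nM.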

Compound 3, half-maximal inhibitory concentration: 1200 nM
Compound 3: the middle estimate sits 3.3-fold (0.52 log units) above what was measured, and the stated range covers the measured number.
By their numbers in this assay, from the lowest: compound 3; then compound 1; then compound 2.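

In this assay, within the data shown here, putting 4-methoxyphenyl in place of 3-methoxybenzyl on an aromatic carbon gives a 2.6-fold lower number from compound 1 to compound 3 (0.41 log units; beyond the scatter), so the group at this end of the shared core, which no earlier step touched, does shift the number. Among these compounds, the step is modest, whereas the only earlier step, at the amide, is large: a 13-fold higher number from compound 1 to compound 2 (1.11 log units; beyond the scatter). The change also alters two things at once, as the methoxy moves from the 3-position label to the 4-position label and benzyl gives way to phenyl, and this single step cannot tell their contributions apart. Nothing measured here offers an explanation for the step.

The compounds shown leave open how a plain phenyl, or a hydroxyl or an amine in place of the methoxy, would behave on this aromatic carbon. They also leave open whether 4-methoxyphenyl gives a comparable step when the (1-bromoethenyl)carbonyl is replaced by hydrogen, as it is in compound 2, or by a simple acetyl group.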